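From Allyl to Ethyl: One Carbon Less on the Chain

This account rests on a few compounds, and the source may have more. Where it says the series, first, only, none or still open, it means among the compounds named here.

Two compounds have so far been measured in a functional assay on CCRF-CEM cells (Homo sapiens) for cytotoxicity, read by MTT assay, with a stated time of 72 h; on this read-out higher numbers stand for lower toxicity in this test and lower numbers for higher toxicity in this test:

Compound 1, `CCCOC(=O)Nc1ccc([Se]C#N)cc1`, gives 68800 nM.
Compound 2, `C=CCOC(=O)Nc1ccc([Se]C#N)cc1`, gives 68600 nM.

Compound 2 holds the lower of the two numbers, but only just: the step of a 1.0-fold lower number from compound 1 to compound 2 (0.00 log units; within the scatter) is within the scatter, so the two compounds cannot be told apart on this read-out.

Compound 3, `CCOC(=O)Nc1ccc([Se]C#N)cc1`, is the next member of the series. It differs from compound 2 in one place: methyl in place of vinyl on a saturated chain carbon bound to an oxygen next to a carbonyl group.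

Among the measured compounds shown here, only one measured step bears on this change. The step of a 1.0-fold lower number from compound 1 to compound 2 (0.00 log units; within the scatter) altered the same chain carbon, exchanging ethyl for vinyl, and produced no shift beyond the scatter. Removing one carbon at that carbon is a change of similar scale, and there is nothing in the measured pair to suggest that the chain length at this position moves the number. The expected step of a 1.0-fold lower number from compound 2 to compound 3 (0.00 log units; within the scatter) is therefore none beyond the scatter.

Compound 3 is accordingly estimated at 68000 nM, with a range of 34000 nM to 136000 nM.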

Compound 3, concentration lethal to 50% of the cells: 68800 nM
Beside the measured number, compound 3's estimate is 1.0-fold (0.01 log units) below it; the measured number falls inside the stated range.
By their numbers in this assay, from the lowest: compounds 2, 1 and 3 (each within the scatter of the next).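

The earlier pair kept the chain length and differed only in its double bond, whereas here the chain itself is one carbon shorter: allyl is replaced by ethyl (a 1.0-fold higher number from compound 2 to compound 3 (0.00 log units; within the scatter)), and the saturated chain of compound 1 is shortened to the ethyl of compound 3 (no change at the digits printed from compound 1 to compound 3 (within the scatter)). Neither the double bond nor the extra chain carbon separates these compounds, so on the evidence of these three, small carbon chains at this position cannot be told apart in this assay. No independent measurement is available that could explain this result.

From the compounds shown here alone, all three compounds carry short carbon chains on the same oxygen, so it remains open whether a much longer chain, a phenyl ring, an amine or a carboxylic acid at this position would give a number beyond the scatter in this assay. Going by these compounds, it also remains open whether the same holds when the rest of the molecule differs, since the shared core and its selenocyanate group stay the same across all three compounds.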